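The compounds below may be only part of what the source reports. "The series", "measured", "known", "first", "only" and "open" are said of these compounds alone.

Measured compounds:
compound 1 `C=Cc1c([C@@H]2O[C@H](CO)[C@@H](O)[C@H]2O)ccnc1C(N)=O`: 152000 nM
compound 2 `CC(C)(C)C(=O)OCOP(=O)(OCOC(=O)C(C)(C)C)OC[C@H]1O[C@@H](c2ccnc(C(N)=O)c2F)[C@H](O)[C@@H]1O`: > 400000 nM

Within the data shown here, compound 1 holds the only number seen in an ADME assay on MDCK cells (Canis lupus familiaris) for cytotoxicity, read by CellTiter-Glo, with a stated time of 10 min; on this read-out lower numbers stand for higher toxicity in this test and higher numbers for lower toxicity in this test; compound 1 gives 152000 nM. Compound 2 reaches only a limit in this assay, > 400000 nM. Compound 3 `NC(=O)c1nccc([C@@H]2O[C@H](CO)[C@@H](O)[C@H]2O)c1F` is still to be measured in this assay; it differs from compound 1 by fluoro in place of vinyl on an aromatic carbon. Among the measured compounds shown here, no measured pair isolates this change. In this assay the step is expected to be small, toward lower toxicity or none beyond the scatter, with the limit of > 400000 nM in this assay, at which 1 of the 2 values shown sits, as the only pointer. For compound 3 the estimate is 250000 nM, range 100000 nM to 600000 nM. This is an expected step of a 1.6-fold higher number from compound 1 to compound 3 (0.22 log units; within the scatter).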

Compound 3, half-maximal cytotoxic concentration: > 400000 nM
Compound 3 ended at the assay's limit; the forecaster's own chance of this, stated with the estimate: 40%; middle value at least 1.6-fold (0.20 log units) from the limit.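

Among these compounds, with fluoro in place of vinyl on an aromatic carbon, ortho to a carbamoyl group, this assay gives the first single-place step: an at least 2.6-fold higher number from compound 1 to compound 3 (0.42 log units; beyond the scatter). On this position, vinyl is therefore the group with the higher toxicity in this test, and the step lies beyond the scatter. Compound 3 reads only a limit of the assay, so the step has a floor and no measured size: the limit of > 400000 nM in this assay, at which 2 of the 3 values shown sit.

The compounds shown leave open whether the number for compound 1 goes with the double bond of vinyl or with the group as a whole. Ethyl or chloro on this aromatic carbon would bear on that.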